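A half-life estimate for a 2-ethylphenyl analogue

The source may report more compounds than this note shows. Statements on the series, on what has been measured and on what is new or still open speak of the compounds shown alone.

In an ADME assay on microsomes from liver (Rattus norvegicus) for metabolic stability, read by LC-MS, using NADPH, at 37 degrees C (on this read-out higher numbers stand for a longer-lived compound and lower numbers for a shorter-lived compound), compound 3 `Cc1cccc(-c2nc(CN3CCC(C(=O)NCCCN4C[C@H](C)C[C@H](C)C4)CC3)c(C)o2)c1` gives > 0.5 h which is a limit and not a number. Compound 1 `Cc1cc(C)c(-c2nc(CN3CCC(C(=O)NCCCN4C[C@H](C)C[C@H](C)C4)CC3)c(C)o2)c(C)c1` gives > 0.5 h which is likewise a limit. Together they make up the limit of > 0.5 h in this assay, at which 2 of the 3 values shown sit, and so leave compound 3 without an exact position. Compound 2 `Cc1oc(-c2c(Cl)cccc2Cl)nc1CN1CCC(C(=O)NCCCN2C[C@H](C)C[C@H](C)C2)CC1` has a measured half-life of 0.0483 h in this assay and carries 2,6-dichlorophenyl. Three steps link these compounds. There is an at least 10-fold lower number from compound 1 to compound 2 (1.01 log units; beyond the scatter) and there is an at least 10-fold higher number from compound 2 to compound 3 (1.01 log units; beyond the scatter) while a step that the two limits leave unreadable from compound 1 to compound 3 adds no readable size. Compound 4 `CCc1ccccc1-c1nc(CN2CCC(C(=O)NCCCN3C[C@H](C)C[C@H](C)C3)CC2)c(C)o1` carries 2-ethylphenyl in place of 3-methylphenyl on an aromatic carbon and has no 2,6-dichlorophenyl group. Both large steps involve compound 2 at 0.0483 h and neither involves this exchange, so no step beyond the scatter is expected. The expected outcome is a number no higher from compound 3 to compound 4 (the limit leaves the size open) in this assay and a reading at the limit would not be surprising. Compound 4 is estimated at 0.5 h with an expected range of 0.15 h to 1 h in this measurement.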

Compound 4, half-life: 0.283 h
For compound 4 the middle estimate is 1.8-fold (0.25 log units) above the measured one; the measured number falls inside the stated range.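

In this assay compound 4 gives 0.283 h, the first exact half-life at this position for any group other than 2,6-dichlorophenyl. The exchange of 2,6-dichlorophenyl for 2-ethylphenyl can therefore be sized in full, as a 5.9-fold higher number from compound 2 to compound 4 (0.77 log units; beyond the scatter). The other two steps are only floors, an at least 1.7-fold lower number from compound 3 to compound 4 (0.24 log units; that floor lies within the scatter) and an at least 1.7-fold lower number from compound 1 to compound 4 (0.24 log units; that floor lies within the scatter), and neither can be sized further because each starts from a limit: the limit of > 0.5 h in this assay, at which 2 of the 4 values shown sit.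

Where compound 1 and compound 3 truly stand remains open, and so does whether compound 4 truly reads lower than they do. The compounds shown also leave open how a 2-chlorophenyl or a 2-methoxyphenyl group would read at this position.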